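Oxazolyl ketone series: ester versus pyridyl amide

A few compounds are considered here, and "the series" means these few. Any claim that something is new, unique, unknown or untested is made for them only; others in the source may bear on it.

Measured so far in an assay for inhibition of Fatty-acid amide hydrolase 1 (Rattus norvegicus); on this read-out lower numbers stand for stronger inhibition and higher numbers for weaker inhibition:
- compound 1, `O=C(O)c1ccc(-c2cnc(C(=O)CCc3ccc(-c4ccccc4)cc3)o2)cn1`, 44 nM
- compound 2, `COC(=O)c1cnc(C(=O)CCc2ccc(-c3ccccc3)cc2)o1`, 1.5 nM

Compound 2 stands lowest of the two numbers in this assay; its nearest neighbour is compound 1, which gives 44 nM. For the measured compounds named here, the only step available is a 29-fold lower number from compound 1 to compound 2 (1.47 log units; beyond the scatter), a large one. Compound 3, `NC(=O)c1ccc(-c2cnc(C(=O)CCc3ccc(-c4ccccc4)cc3)o2)nc1`, differs from compound 2 by 5-carbamoylpyridin-2-yl in place of methoxycarbonyl on an aromatic carbon. This reverses the direction of that step: a pyridinyl bearing a carbonyl group returns in place of the methoxycarbonyl, as in compound 1. A large step upward in this assay is therefore expected, estimated at a 13-fold higher number from compound 2 to compound 3 (1.12 log units; beyond the scatter). Compound 3 is expected to give about 20 nM, within 5 nM to 80 nM.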

Compound 3, inhibition constant: 1.3 nM
Compound 3: the middle estimate sits 15-fold (1.19 log units) above what was measured, and the stated range ends above it.
By their numbers in this assay, from the lowest: compounds 3 and 2 (each within the scatter of the next); then compound 1.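

With a 1.2-fold lower number from compound 2 to compound 3 (0.06 log units; within the scatter) in this assay, the aromatic carbon next to the ring oxygen carries 5-carbamoylpyridin-2-yl and methoxycarbonyl without a difference beyond the scatter. A pyridinyl group here therefore does not in itself bring the higher number of compound 1, and a 34-fold lower number from compound 1 to compound 3 (1.53 log units; beyond the scatter) separates the two pyridinyl-bearing compounds. No measured evidence bears on the reason for this gap.

The two pyridinyl groups differ in both the carbonyl substituent and the ring attachment, leaving their contributions unresolved. A 5-carboxypyridin-2-yl group would separate the carboxylic acid from the attachment.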